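Swapping Fluoro for Methoxy Across Two Related Cores

The source may report more compounds than this note shows. Statements on the series, on what has been measured and on what is new or still open speak of the compounds shown alone.

Of the compounds shown here, three have been measured in a functional assay on HL-60 cells (Homo sapiens) for cytotoxicity, read by MTT assay, with a stated time of 4 days; a lower number here means a stronger inhibitor, a higher number a weaker inhibitor.
Compound 1 `C=C1C(=O)[C@]23C[C@@]1(O)CC[C@H]2c1ccc(O)c(C)c1[C@@H]3Cn1cc(-c2ccc(F)cc2)nn1` gives 660 nM.
Compound 3 `C=C1C(=O)[C@]23C[C@@]1(O)CC[C@H]2c1ccc(O)c(C)c1[C@@H]3Cn1cc(-c2ccc(OC)cc2)nn1` gives 1150 nM.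
Compound 2 `C=C1C[C@]23C[C@@]1(O)CC[C@H]2c1ccc(O)c(C)c1[C@@H]3Cn1cc(-c2ccc(F)cc2)nn1` is reported only as a limit, > 20000 nM.

Compound 1 and compound 3 share one core and differ by methoxy in place of fluoro on an aromatic carbon. That change gave a 1.7-fold higher number from compound 1 to compound 3 (0.24 log units; within the scatter), so the two values cannot be told apart. Compound 2 rests on a second core; how the two cores differ is not broken down here. Compound 4 `C=C1C[C@]23C[C@@]1(O)CC[C@H]2c1ccc(O)c(C)c1[C@@H]3Cn1cc(-c2ccc(OC)cc2)nn1` has not yet been measured and differs from compound 2 by methoxy in place of fluoro on an aromatic carbon, the same change made at the same place. Since compound 2 already sits at the limit of > 20000 nM in this assay, at which 1 of the 3 values shown sits, compound 4 is expected to stay near that limit as well, with a step estimated as a step that the limit leaves unreadable from compound 2 to compound 4. The estimate for compound 4 is 30000 nM, from 15000 nM to 80000 nM.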

Compound 4, half-maximal inhibitory concentration: > 20000 nM
Compound 4 gave a limit, no number; the forecaster's own chance of this, stated with the estimate: 85%; the middle value lies beyond the limit too.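

Compound 2 and compound 4 both sit at a limit of the assay rather than at a number, so no step between them can be read: the limit of > 20000 nM in this assay, at which 2 of the 4 values shown sit.

The compounds shown leave open whether methoxy in place of fluoro changes anything on this core.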